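Swapping a fluorine for a chlorine on a kinase inhibitor

The source may hold more compounds than are shown below. What is called first, only, known or untested is meant among the compounds shown, and "the series" means these compounds.

Of the compounds shown here, three built on one shared core have been measured in an assay on isolated protein for inhibition of G protein-coupled receptor kinase 6 (Homo sapiens), read by scintillation counting, radiometric assay and 33P incorporation, with a stated time of 80 min, in the presence of a further agent that is not named here; on this read-out lower numbers stand for stronger inhibition and higher numbers for weaker inhibition. Compound 2 `CCc1cc(Nc2nc(N[C@H](C)c3ccc(F)cc3)nc3ccccc23)n[nH]1` gives 1400 nM, the highest number of the three, which on this read-out means the weakest inhibition. Compound 1 `CCc1cc(Nc2nc(NC3(c4ccc(Cl)cc4)CC3)nc3ccccc23)n[nH]1` gives 280 nM in this assay, and compound 3 `CCc1cc(Nc2nc(N[C@@H](C)c3ccc(F)cc3)nc3cc(F)ccc23)n[nH]1` gives 100 nM, the lowest number of the set. No direct single-point comparisons between the measured compounds exist, so the three values can only be set side by side.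

Compound 4 `CCc1cc(Nc2nc(N[C@@H](C)c3ccc(Cl)cc3)nc3ccccc23)n[nH]1` has not yet been measured. It differs from compound 2 in one place: 1-(4-chlorophenyl)ethyl in place of 1-(4-fluorophenyl)ethyl on a nitrogen on an aromatic ring. The pieces that leave and enter match each other closely, and the only difference is the halogen on the ring.

Going by the values given here, with no measured step of this exact kind to lean on, the direction of change rests on the other two compounds. Compound 1, which also carries a chlorine on its aromatic ring, gives 280 nM, a markedly lower number than compound 2. On that basis the expected step is a 4.0-fold lower number from compound 2 to compound 4 (0.60 log units; beyond the scatter), a clear move toward stronger inhibition. Compound 4 is therefore estimated at 350 nM in this assay, with a plausible range from 90 nM to 1300 nM.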

Compound 4, half-maximal inhibitory concentration: 70 nM
Compound 4: the middle estimate sits 5.0-fold (0.70 log units) above what was measured; the measured number lies below the stated range.
By their numbers in this assay, from the lowest: compounds 4 and 3 (each within the scatter of the next); then compound 1; then compound 2.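

In this assay, putting 1-(4-chlorophenyl)ethyl in place of 1-(4-fluorophenyl)ethyl on a nitrogen on an aromatic ring gives a 20-fold lower number from compound 2 to compound 4 (1.30 log units; beyond the scatter) and thus shows that this position can respond strongly even when the heavy-atom count, hydrogen-bond counts and charge of the group stay the same. The written structures also show opposite handedness at the defined stereocentre of this group, so the step cannot be credited to the halogen alone, even though the two groups have the same name apart from that halogen. Nothing measured here explains why the step is this large.

The compounds shown leave open how much of the step belongs to the halogen and how much to the handedness, which only a fluorine and chlorine pair of matching handedness could separate. They also leave open how the same position would read with a bromine, a methyl or a nitrile in place of the halogen, or with a phenyl ring carrying no halogen at all.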